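The source may report more compounds than this note shows. Statements on the series, on what has been measured and on what is new or still open speak of the compounds shown alone.

Compound 1 `Cn1c(=O)c(S(=O)(=O)c2ccc(F)cc2F)cc2cnc(Nc3ccc4[nH]ncc4c3)nc21`: 30000 nM
Compound 2 `Cn1c(=O)c(S(=O)(=O)c2ccc(F)cc2F)cc2cnc(Nc3ccc4cc[nH]c4c3)nc21`: 5000 nM

In a functional assay on DU-145 cells (Homo sapiens) for inhibition, read by trypan blue exclusion, with a stated time of 72 h (a higher number here means a weaker inhibitor, a lower number a stronger inhibitor), compound 2 has the lower of the two numbers, at 5000 nM. Compound 3 `Cc1cc2cc(Nc3ncc4cc(S(=O)(=O)c5ccc(F)cc5F)c(=O)n(C)c4n3)ccc2[nH]1` differs from compound 2 by one change: 2-methyl-1H-indol-5-yl in place of 1H-indol-6-yl on a nitrogen on an aromatic ring. It carries 2-methyl-1H-indol-5-yl in place of 1H-indol-6-yl on a nitrogen on an aromatic ring. Within the data shown here, only one measured step bears on this, a modest one at the same place: a 6.0-fold lower number from compound 1 to compound 2 (0.78 log units; beyond the scatter). Among the measured compounds shown here, no measured compound carries 2-methyl-1H-indol-5-yl, so that step hints at a plausible size but gives no direction. The expected change is small and stays within the scatter: a 1.2-fold higher number from compound 2 to compound 3 (0.08 log units; within the scatter). For compound 3, the estimated value is 6000 nM, with an expected range of 1500 nM to 25000 nM.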

Compound 3, half-maximal inhibitory concentration: 750 nM
Estimate against measurement, compound 3: 8.0-fold (0.90 log units) above, outside the stated range (below it).
By their numbers in this assay, from the lowest: compound 3; then compound 2; then compound 1.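

In this assay, the group on this nitrogen still has a strong hold on the number: moving to 2-methyl-1H-indol-5-yl gives a further gain (a 6.7-fold lower number from compound 2 to compound 3 (0.82 log units; beyond the scatter)), and the distance from the indazole compound is larger still (a 40-fold lower number from compound 1 to compound 3 (1.60 log units; beyond the scatter)). This one swap both adds a methyl and changes the indole from a 6-yl to a 5-yl group. Nothing measured here accounts for the gain.

Plain 1H-indol-5-yl would be needed to separate those two differences. As far as these compounds go, whether an ethyl or an aminomethyl group could replace the methyl also remains open.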